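The compounds below may be only part of what the source reports. "The series", "measured", "known", "first", "only" and "open" are said of these compounds alone.

Series notes. Compound 1 `CC(=O)N1CCC(C(=O)N2N=CCC2c2ccccc2)CC1` and compound 3 `CC(=O)N1CCC(C(=O)N2N=CC[C@H]2c2ccccc2)CC1` share the same atoms and bonds and differ only in whether the stereocentre at a saturated ring carbon is drawn with a configuration. In a physicochemical assay for lipophilicity, read by HPLC, measured as chromatographic lipophilicity, at pH 7.4 (a lower number here means a more polar compound, a higher number a more lipophilic compound), compound 1 gives 2.5, and compound 3 gives 2.5; no change at the digits printed from compound 1 to compound 3 (within the scatter), which fits with the fact that one of compounds 1 and 3 is drawn with a defined configuration and the other without, at the place where they differ. Compound 2 `C[C@@H]1C=NN(C(=O)C(C)(C)C)[C@@H]1c1ccccc1` stands apart in this assay at 6.5, a number far higher than the other two and beyond the scatter. Compound 1 and compound 3 thus sit together as the lowest of the three numbers.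

Compound 4 `O=C(c1c[nH]nn1)N1CCC(C(=O)N2N=CCC2c2ccccc2)CC1` has not yet been measured. It differs from compound 1 by 1H-1,2,3-triazol-4-yl in place of methyl on a carbonyl carbon. For the measured compounds named here, none of the measured steps covers a change of this kind: the single measured step, from compound 1 to compound 3, concerns only a drawn configuration and gave no change, and no pair among the measured compounds shows an exchange on the carbonyl carbon attached to the ring nitrogen. The expectation therefore rests on the nature of the change alone, with 1H-1,2,3-triazol-4-yl entering where methyl leaves. On that basis a downward step in this assay is expected, a number 0.70 log units lower from compound 1 to compound 4 (beyond the scatter), beyond the scatter but moderate in size. Compound 4 is expected to give 1.8 in this assay, within a range from 1 to 2.6.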

Compound 4, distribution coefficient: 2
For compound 4 the middle estimate is 0.20 log units below the measured one; measured number inside the range.
By their numbers in this assay, from the lowest: compound 4; then compounds 1 and 3 (each within the scatter of the next); then compound 2.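

In this assay, for the compounds shown here, the exchange of methyl for 1H-1,2,3-triazol-4-yl on the carbonyl carbon gives a number 0.50 log units lower from compound 1 to compound 4 (beyond the scatter) and is the first measured change at this position, since the earlier step among the closely related compounds concerned only a drawn configuration. The acetyl to (1H-1,2,3-triazol-4-yl)carbonyl exchange replaces a single carbon with a larger group carrying a five-membered aromatic ring, a hydrogen-bond donor and hydrogen-bond acceptors, and the read-out still moves by only a modest step. The one available explanatory note concerns the drawn configuration and has no bearing on this exchange.

From the compounds shown here alone, a single exchange fixes no trend at this position, so it remains open whether an amine, a carboxylic acid or a longer chain on the same carbonyl carbon would move the number in the same direction, and by how much. Going by these compounds, it also remains open whether a methyl-substituted triazole, without the ring hydrogen on nitrogen, would give a step like this one, and whether a form of compound 4 with a defined configuration would match it, as the pair of compounds 1 and 3 does.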